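A few compounds are considered here, and "the series" means these few. Any claim that something is new, unique, unknown or untested is made for them only; others in the source may bear on it.

Measured compounds:
- compound 1, `COc1cc(-c2nn(-c3cccc(NC(=O)c4ccc(Cl)c(C(F)(F)F)c4)c3)cc2-c2ccncc2)ccc1Cl`: 11000 nM
- compound 2, `O=C(Nc1cccc(-n2cc(-c3ccncc3)c(-c3ccc(Cl)c(O)c3)n2)c1)Nc1cc(C(F)(F)F)cc(C(F)(F)F)c1`: 1170 nM
- compound 3, `O=C(Nc1cccc(-n2cc(-c3ccncc3)c(-c3ccc(Cl)c(O)c3)n2)c1)Nc1ccc(Cl)c(C(F)(F)F)c1`: 1280 nM

All three were tested in a functional assay on 786-0 cells (Homo sapiens) for inhibition, read by sulforhodamine B assay, with a stated time of 48 h; on this read-out higher numbers stand for weaker inhibition of growth and lower numbers for stronger inhibition of growth. Compound 1 gives the highest of the three numbers, so it is the weakest of the set: the nearest is compound 3, and the gap to it lies beyond the scatter, as does the gap to compound 2. For the measured compounds named here, compounds 2 and 3 both carry a urea rather than the amide of compound 1, and they also differ from compound 1 elsewhere, so no single step between measured compounds is available.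

Compound 4, `COc1cc(-c2nn(-c3cccc(NC(=O)Nc4ccc(Cl)c(Cl)c4)c3)cc2-c2ccncc2)ccc1Cl`, is a new compound still to be measured in this assay. It keeps the core of compound 1 and changes one place: (3,4-dichlorophenyl)amino in place of 4-chloro-3-(trifluoromethyl)phenyl on a carbonyl carbon.

The urea compounds 2 and 3 both gave far lower numbers than the amide compound 1, but they carry a second difference, so how much of that gap comes from the urea alone is not known. A lower number than that of compound 1 is nevertheless expected for compound 4, with the step of a 3.7-fold lower number from compound 1 to compound 4 (0.56 log units; beyond the scatter) expected to lie beyond the scatter. The estimate for compound 4 is 3000 nM, within a range from 1000 nM to 9000 nM.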

Compound 4, concentration for 50% growth inhibition: 1310 nM
Compound 4: middle estimate off by 2.3-fold (0.36 log units), on the high side; the measured number falls inside the stated range.
By their numbers in this assay, from the lowest: compounds 2, 3 and 4 (each within the scatter of the next); then compound 1.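

In this assay, for the compounds shown here, the swap on the carbonyl carbon gives an 8.4-fold lower number from compound 1 to compound 4 (0.92 log units; beyond the scatter) and is the first change in this set made in one place only, so it shows that what sits on this carbonyl carbon matters for growth inhibition on the core of compound 1. The swap turns the amide into a urea while keeping a six-membered aromatic ring of carbon only, and the entering (3,4-dichlorophenyl)amino counts a hydrogen-bond donor that the leaving 4-chloro-3-(trifluoromethyl)phenyl does not. Nothing measured here explains why the number falls.

From the compounds shown here alone, this single step still bundles two differences, the new amino nitrogen and the second chlorine in place of trifluoromethyl, so the share of each in the step remains unknown. A (4-chloro-3-(trifluoromethyl)phenyl)amino group on this same core would pull the two apart, and a cyclohexylamino group, which has no aromatic ring, would test whether the urea needs an aromatic ring at all.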